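This account rests on a few compounds, and the source may have more. Where it says the series, first, only, none or still open, it means among the compounds named here.

Measured so far in a functional assay on MDA-MB-468 cells (Homo sapiens) for inhibition, read by sulforhodamine B assay, with a stated time of 48 h; on this read-out higher numbers stand for weaker inhibition and lower numbers for stronger inhibition: compound 1 `COc1cc(-c2nn(-c3cccc(NC(=O)Nc4ccc(Cl)c(Cl)c4)c3)cc2-c2ccncc2)ccc1Cl` gives 570 nM; compound 2 `O=C(Nc1cccc(-n2cc(-c3ccncc3)c(-c3ccc(Cl)c(O)c3)n2)c1)Nc1ccc(Cl)c(Cl)c1` gives 730 nM.

Within the data shown here, compound 1 and compound 2 sit within the scatter of each other, the only measured step being a 1.3-fold higher number from compound 1 to compound 2 (0.11 log units; within the scatter), hydrogen in place of methyl on an oxygen on an aromatic ring. Compound 3 `COc1cc(-c2nn(-c3cccc(NC(=O)Nc4ccc(Cl)c(C(F)(F)F)c4)c3)cc2-c2ccncc2)ccc1Cl` differs from compound 1 by trifluoromethyl in place of chloro on an aromatic carbon. Among the measured compounds shown here, no measured step touches that ring, so nothing here argues for a shift beyond the scatter in this assay. Compound 3 is therefore expected to stay close to compound 1, with an estimated step of a 1.1-fold higher number from compound 1 to compound 3 (0.02 log units; within the scatter). The estimate for compound 3 is 600 nM, range 250 nM to 1400 nM.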

Compound 3, half-maximal inhibitory concentration: 830 nM
The estimate for compound 3 lay 1.4-fold (0.14 log units) below the measured number; low and high end bracket the measured number.
By their numbers in this assay, from the lowest: compounds 1, 2 and 3 (each within the scatter of the next).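

In this assay, among these compounds, the first measured change on the 3,4-dichlorophenyl end shows that this position, ortho to a chloro group, accepts trifluoromethyl, with four heavy atoms in place of one, without a shift beyond the scatter (a 1.5-fold higher number from compound 1 to compound 3 (0.16 log units; within the scatter)). The earlier step touched only the oxygen on the other aromatic ring. No supporting data explain this tolerance.

On these data alone, whether an amine or a carboxylic acid at this position would keep the number within the scatter remains open. So does the outcome of replacing the remaining chloro group.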